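A few compounds are considered here, and "the series" means these few. Any claim that something is new, unique, unknown or untested is made for them only; others in the source may bear on it.

Compound 1, `CS/C(=N\C(=O)c1csc([N+](=O)[O-])c1)NC(=O)c1csc([N+](=O)[O-])c1`, in a functional assay on MCF7 cells (Homo sapiens) for cytotoxicity, read by MTT assay, with a stated time of 72 h (a lower number here means a stronger inhibitor of growth, a higher number a weaker inhibitor of growth), gives 78100 nM.
Compound 2, `C[Se]/C(=N\C(=O)c1cccs1)NC(=O)c1cccs1`, in this assay gives 5640 nM.
Compound 3, `O=C(/N=C(/NC(=O)c1cc(-c2ccccc2)nc2ccccc12)[Se]Cc1ccccc1)c1cc(-c2ccccc2)nc2ccccc12`, in this assay gives 45600 nM.

Among these three, compound 2 has the lowest number, so it is the strongest inhibitor of growth shown; the gap to compound 3, the nearest, and the larger gap to compound 1 both lie beyond the usual scatter of this measurement.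

Compound 4, `O=C(/N=C(/NC(=O)c1cccs1)[Se]Cc1ccccc1)c1cccs1`, has not yet been measured. It differs from compound 2 in one place: phenyl in place of hydrogen on a saturated chain carbon bound to a selenium atom. Going by the values given here, no measured pair shows this exact change on a shared core, so the size of the step cannot be read from the data. Compound 3 carries the same benzyl group on selenium but a different core, and its value is simply higher than that of compound 2; that gives no direct guide. A modest weakening, or no change beyond the scatter, seems the most likely outcome.

Compound 4 is therefore expected to give about 8000 nM, within a range from 2500 nM to 25000 nM. The expected step is a 1.4-fold higher number from compound 2 to compound 4 (0.15 log units; within the scatter).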

Compound 4, concentration for total growth inhibition: > 100000 nM
Compound 4 gave a limit, no number; the forecaster's own chance of this, stated with the estimate: 10%; at least 12-fold (1.09 log units) between middle value and limit.
By their numbers in this assay, from the lowest: compound 2; then compounds 3 and 1 (each within the scatter of the next). At a limit, above all of these: compound 4.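

In this assay, going by these compounds alone, the first direct comparison of this change on a shared core is large: phenyl in place of hydrogen on a saturated chain carbon bound to a selenium atom gives an at least 17-fold higher number from compound 2 to compound 4 (1.24 log units; beyond the scatter). On this core, then, the group on selenium is far from a neutral place to make a change, since going from methyl to benzyl alone removes most or all of the growth inhibition seen with compound 2. Compound 4 gives > 100000 nM, a limit and not a number, so the full size of the step stays unknown: the limit of > 100000 nM in this assay, at which 1 of the 4 values shown sits.

On this core, only methyl and benzyl are shown on selenium, so it stays open whether an ethyl group or a longer chain without the ring would keep the activity of compound 2. As far as these compounds go, it also stays open whether an amine at the end of such a chain would do so.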